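This account rests on a few compounds, and the source may have more. Where it says the series, first, only, none or still open, it means among the compounds named here.

The measured compounds are:

compound 1, `O=C(NC(=S)Nc1nc2cc([N+](=O)[O-])ccc2s1)N1CCOCC1`, with 54800 nM in a functional assay on HeLa cells (Homo sapiens) for cytotoxicity, read by MTT assay, with a stated time of 24 h; on this read-out higher numbers stand for weaker inhibition and lower numbers for stronger inhibition;
compound 2, `O=C(NC(=S)Nc1nc2ccccc2s1)N1CCOCC1`, with 51800 nM in this assay;
compound 3, `O=C(NC(=S)Nc1nc2cc(Br)ccc2s1)c1ccc([N+](=O)[O-])cc1`, with 56500 nM in this assay.

Compound 1 and compound 2 share a core and differ in one place: hydrogen in place of nitro on an aromatic carbon. The step that this change made is a 1.1-fold lower number from compound 1 to compound 2 (0.02 log units; within the scatter). Compound 3 carries a different core; how it differs from compound 1 is not broken down here. Compound 3 and compound 1 give numbers within the scatter of each other, as do compound 3 and compound 2, so nothing in the three measurements separates them.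

Compound 4, `O=C(NC(=S)Nc1nc2cc(Br)ccc2s1)c1ccccc1`, has not yet been measured. It differs from compound 3 as follows: hydrogen in place of nitro on an aromatic carbon. This is the same kind of change as that from compound 1 to compound 2, but not the same: in the first case the place is an aromatic carbon of a six-membered aromatic ring of carbon only, part of a fused or bridged system of two rings, meta to a fused ring and para to a fused ring; in the second case it is an aromatic carbon of a six-membered aromatic ring of carbon only, para to a large group.

The expectation for compound 4 rests on the step of a 1.1-fold lower number from compound 1 to compound 2 (0.02 log units; within the scatter), which lay within the scatter. On that basis the step from compound 3 to compound 4 is expected to be a 1.0-fold lower number from compound 3 to compound 4 (0.01 log units; within the scatter). Compound 4 is thus estimated at 55000 nM in this assay, with a range from 25000 nM to 120000 nM.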

Compound 4, half-maximal inhibitory concentration: 64600 nM
Compound 4: middle estimate off by 1.2-fold (0.07 log units), on the low side; the measured number falls inside the stated range.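

On the core of compound 3, hydrogen in place of nitro gives a 1.1-fold higher number from compound 3 to compound 4 (0.06 log units; within the scatter) in this assay, so this step, like the earlier one, does not stand out from the scatter. Set side by side, the two steps give no sign that the outcome of this change depends on the core, even though the nitro group sits on the fused ring system in one pair and, in the other, on an aromatic carbon para to a large group: the same change on two cores in this assay, a 1.1-fold lower number (0.02 log units; within the scatter) from compound 1 to compound 2 and a 1.1-fold higher number (0.06 log units; within the scatter) from compound 3 to compound 4, 1.2-fold (0.08 log units) apart, within the scatter of two such steps. This shows that the change carried over in the limited sense that it left the number within the scatter on both cores, but it does not show a shared effect of nitro, and the opposite directions of the two small steps carry no meaning, nor can the two pairs tell whether the core or the place matters on any other change.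

The compounds shown hold only nitro or hydrogen at these places, so it remains open whether an amine, a carboxylic acid or a longer alkyl chain there would give a step beyond the scatter. As far as these compounds go, it also remains open whether replacing the bromo group on the core of compound 4 with hydrogen would move the number at all.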